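This account rests on a few compounds, and the source may have more. Where it says the series, first, only, none or still open, it means among the compounds named here.

Measured so far in an ADME assay on HaCaT cells (Homo sapiens) for cytotoxicity, read by MTT assay, with a stated time of 72 h; a lower number here means a stronger inhibitor, a higher number a weaker inhibitor:
compound 1 `Cc1cc(-c2ccccc2)n(/C(N)=N/S(=O)(=O)c2cc(C)c(Cl)cc2SCc2ccc(C(F)(F)F)cc2)n1` gives 18000 nM
compound 2 `Cc1cc(-c2ccccc2)n(/C(N)=N/S(=O)(=O)c2cc(C)c(Cl)cc2SCc2cccc3ccccc23)n1` gives 12000 nM
compound 3 `Cc1cc(S(=O)(=O)/N=C(\N)n2nccc2-c2ccccc2)c(SCc2ccccc2C)cc1Cl` gives 18000 nM

Compound 3 stands level with compound 1 at the digits shown, and these two together give the highest numbers of the three, while compound 2 comes out somewhat lower, though still within the scatter of both. Among the compounds with values here, the only measured step that changes a single place is a 1.5-fold lower number from compound 1 to compound 2 (0.18 log units; within the scatter), in which naphthalen-1-yl takes the place of 4-(trifluoromethyl)phenyl on a saturated chain carbon bound to a sulfur; it stays within the scatter.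

Compound 4 `Cc1cc(S(=O)(=O)/N=C(\N)n2nccc2-c2ccccc2)c(SCc2cccc(C(F)(F)F)c2)cc1Cl` has not yet been measured. It differs from compound 3 in one place: 3-(trifluoromethyl)phenyl in place of 2-methylphenyl on a saturated chain carbon bound to a sulfur. This is the same place that is changed in the measured step, and that step brought no shift beyond the scatter. Compound 1 and compound 3, which also differ in the group at this place, give the same number at the digits shown. Nothing measured here points to a change beyond the scatter for compound 4, so the expected step is a 1.1-fold lower number from compound 3 to compound 4 (0.05 log units; within the scatter). Compound 4 is therefore estimated at 16000 nM in this assay, with a likely range from 7000 nM to 35000 nM.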

Compound 4, half-maximal inhibitory concentration: 18000 nM
Beside the measured number, compound 4's estimate is 1.1-fold (0.05 log units) below it; the measured number falls inside the stated range.
By their numbers in this assay, from the lowest: compounds 2, 1, 3 and 4 (each within the scatter of the next).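

In this assay, the change to 3-(trifluoromethyl)phenyl in place of 2-methylphenyl on a saturated chain carbon bound to a sulfur gives no change at the digits printed from compound 3 to compound 4 (within the scatter), although the entering group has 10 heavy atoms and the leaving group 7. With a 1.5-fold lower number from compound 1 to compound 2 (0.18 log units; within the scatter), there are now two single-place changes at this position, made on two different cores, and neither moves the number beyond the scatter, so the flat result is no longer confined to one pair of compounds. No measurement is available that bears on why these numbers hold steady here.

Within the data shown here, every group at this position so far carries only carbon-based aromatic rings, so it remains open whether a cyclohexyl ring, or a phenyl ring bearing an amine or a carboxylic acid, would shift the number beyond the scatter. With no step at this position yet beyond the scatter, the groups shown cannot be put in any order, and the two pairs say nothing about changes elsewhere on the core.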